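A few compounds are considered here, and "the series" means these few. Any claim that something is new, unique, unknown or untested is made for them only; others in the source may bear on it.

Of the compounds shown here, two built on a shared core have so far been measured in a functional assay on J774 cells (Mus musculus) for cytotoxicity, read by resazurin assay, with a stated time of 72 h; on this read-out lower numbers stand for stronger inhibition and higher numbers for weaker inhibition. Compound 1, `Cc1cc(S(=O)(=O)Nc2cccc(CO)c2)ccc1-c1ccc(F)cc1F`, gives 100 nM in this assay. Compound 2, `Cc1c(CO)cccc1NS(=O)(=O)c1ccc(-c2ccc(F)cc2F)cc1`, gives 80 nM in this assay. Of these two numbers, compound 2 holds the lower one, but its gap to compound 1 falls within the scatter, so the pair shows one level of potency rather than a ranking.

Compound 3, `Cc1cc(S(=O)(=O)Nc2cccc(CO)c2C)ccc1-c1ccc(F)cc1F`, has not yet been measured. It differs from compound 2 in a single place: methyl in place of hydrogen on an aromatic carbon, a methyl in place of hydrogen on an aromatic carbon, placed ortho to the 2,4-difluorophenyl group. Within the data shown here, no measured pair in this set shows what such a change does, so there is no step to lean on. With one carbon added and everything else kept, the expectation is a small shift in this assay, in no particular direction and not beyond the scatter. The expected step of a 1.3-fold higher number from compound 2 to compound 3 (0.10 log units; within the scatter) is therefore modest. Compound 3 is estimated at 100 nM, with a range from 35 nM to 300 nM.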

Compound 3, half-maximal inhibitory concentration: 25 nM
For compound 3 the middle estimate is 4.0-fold (0.60 log units) above the measured one; the whole stated range lies above it.
By their numbers in this assay, from the lowest: compound 3; then compounds 2 and 1 (each within the scatter of the next).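

In this assay, adding one methyl ortho to a 2,4-difluorophenyl group gives a 3.2-fold lower number from compound 2 to compound 3 (0.51 log units; beyond the scatter), a change beyond the scatter, so this aromatic carbon does respond to a very small addition. The other comparison points the same way: the step is a 4.0-fold lower number from compound 1 to compound 3 (0.60 log units; beyond the scatter), also beyond the scatter, and compound 3, which carries the methyl groups of both compound 1 and compound 2, is the most potent of the three in this assay. Nothing available here accounts for why one extra carbon has this effect.

As far as these compounds go, these three compounds show only hydrogen and methyl at this place, so it remains open whether an ethyl group, a chlorine atom or a methoxy group on the same aromatic carbon would strengthen the effect, keep it or lose it. From the compounds shown here alone, it is also open whether the gain depends on the hydroxymethyl group elsewhere in the molecule, which a matching compound with a carboxylic acid or an amine there could test.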